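The source may hold more compounds than are shown below. What is called first, only, known or untested is meant among the compounds shown, and "the series" means these compounds.

Measured so far in a functional assay on MCF7 cells (Homo sapiens) for inhibition, read by sulforhodamine B assay; on this read-out lower numbers stand for stronger inhibition and higher numbers for weaker inhibition:

compound 1 `O=C1C(NC2CC2)=CC(=O)c2c1nc1n2[C@H]2OC[C@@H](O)[C@H]2OC1` — in this assay compound 1 gives > 16000 nM, a limit of the assay, not a number.
compound 2 `COc1cccc(NC2=CC(=O)c3nc4n(c3C2=O)[C@H]2OC[C@@H](O)[C@H]2OC4)c1` — in this assay compound 2 gives > 4000 nM, again a limit.
compound 3 `O=C1C=C(NC2CCCCC2)C(=O)c2c1nc1n2[C@H]2OC[C@@H](O)[C@H]2OC1` — in this assay compound 3 gives > 8000 nM, again a limit.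

Compound 1 stands at a limit only, as do the other two values (the limit of > 16000 nM in this assay, at which 1 of the 3 values shown sits, (the limit of > 4000 nM in this assay, at which 1 of the 3 values shown sits), (the limit of > 8000 nM in this assay, at which 1 of the 3 values shown sits)). Since none of the three is a number, no order among them can be read. Among the measured compounds shown here, the single step between measured neighbours, a step that the two limits leave unreadable from compound 2 to compound 3, is likewise unreadable, both of its ends being limits.

Compound 4 `O=C1C(Nc2ccccc2)=CC(=O)c2c1nc1n2[C@H]2OC[C@@H](O)[C@H]2OC1` differs from compound 1 by phenyl in place of cyclopropyl on an amine nitrogen. For the measured compounds named here, the only measured step that bears on a change at the amine nitrogen is a step that the two limits leave unreadable from compound 2 to compound 3, and it gives no size. With every value in the series sitting at a limit, a further limit is the most likely outcome for compound 4, and the step of an at least 1.3-fold lower number from compound 1 to compound 4 (0.12 log units; that floor lies within the scatter) is expected to be no more than scatter. Compound 4 is estimated at 12000 nM, within a range of 3000 nM to 50000 nM.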

Compound 4, half-maximal inhibitory concentration: > 4000 nM
Compound 4: a limit, no number; the forecaster's own chance of this, stated with the estimate: 75%; the middle value does not contradict the limit.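

Compound 1 and compound 4 both sit at limits of the assay, not numbers, and the step between them cannot be read. The compounds shown leave open whether any group on the amine nitrogen changes inhibition, and where any of the four would give an actual number.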